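Swapping the aryl group on the shared core

A few compounds are considered here, and "the series" means these few. Any claim that something is new, unique, unknown or untested is made for them only; others in the source may bear on it.

In an in vivo ADME assay on the whole organism for metabolic stability, with Rattus norvegicus as the target, using cassette dosing (a higher number here means that the compound lasts longer, a lower number that the compound disappears faster), compound 3 `Cc1ccccc1[C@@]1(O)C[C@H](C(=O)Nc2ccc(-n3ccccc3=O)cn2)N(C(=O)Nc2ccc(Cl)cc2)C1` gives 1.3 h. Compound 1 `CO[C@]1(C)C[C@H](C(=O)Nc2ccc(-n3ccccc3=O)cc2F)N(C(=O)Nc2ccc(Cl)cc2)C1` gives 1.7 h, a gap within the usual scatter, while compound 2 `O=C(Nc1ccc(-n2ccccc2=O)cn1)[C@H]1C[C@](O)(c2ccccc2)CN1C(=O)Nc1ccc(Cl)cc1` gives 2.9 h, a gap beyond it, so compound 3 sits at the low end of the three. Going by the values given here, the only measured step that touches compound 3 is a 2.2-fold lower number from compound 2 to compound 3 (0.35 log units; beyond the scatter). Compound 4 `O=C(Nc1ccc(-n2ccccc2=O)cn1)[C@H]1C[C@](O)(c2ccc(F)c(F)c2)CN1C(=O)Nc1ccc(Cl)cc1` differs from compound 3 by 3,4-difluorophenyl in place of 2-methylphenyl on a saturated ring carbon. Among the compounds with values here, this change takes away the methyl whose arrival marked that earlier step, which points to a modest rise, but the two fluorines have no measured counterpart, so the expected step in this assay is a 1.7-fold higher number from compound 3 to compound 4 (0.23 log units; within the scatter). Compound 4 is therefore estimated at about 2.2 h, between 1.2 h and 4 h.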

Compound 4, half-life: 2.1 h
Beside the measured number, compound 4's estimate is 1.0-fold (0.02 log units) above it; the range from low to high includes it.
By their numbers in this assay, from the lowest: compounds 3, 1, 4 and 2 (each within the scatter of the next, the first and the last beyond it).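

On this saturated ring carbon, 3,4-difluorophenyl cannot be told apart from either of the other aryl groups in this assay, since a 1.6-fold higher number from compound 3 to compound 4 (0.21 log units; within the scatter) and a 1.4-fold lower number from compound 2 to compound 4 (0.14 log units; within the scatter) both stay within the scatter. Among these three aryl groups, only the swap of phenyl for 2-methylphenyl gives a step beyond the scatter, so the two fluorines on phenyl leave the half-life within the range of repeat measurements.

Going by these compounds, how a non-aromatic group such as cyclohexyl, or an aromatic ring bearing an amine, would behave on this carbon stays open. Nothing measured here explains any of these steps.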